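Adding trifluoromethoxy to compound 2

The source may report more compounds than this note shows. Statements on the series, on what has been measured and on what is new or still open speak of the compounds shown alone.

In a functional assay on HepG2 cells (Homo sapiens) for cytotoxicity, with a stated time of 72 h (on this read-out lower numbers stand for an effect already at smaller amounts and higher numbers for an effect only at larger amounts of compound), compound 2 `C=C[C@@](C)(/C=C/c1ccc(Nc2ccccc2)cc1)CCC=C(C)C` gives > 52000 nM, and this figure is a limit, not a number. Compound 1 `C=C[C@@](C)(/C=C/c1ccc(OS(=O)(=O)C(F)(F)F)cc1)CCC=C(C)C` gives > 52000 nM, which is also a limit. Compound 3 `C=C[C@@](C)(/C=C/c1ccc(Nc2ccc(OC)c(F)c2)cc1)CCC=C(C)C` gives > 52000 nM, again a limit. The three compounds therefore share one mark: the limit of > 52000 nM in this assay, at which 3 of the 3 values shown sit.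

Compound 4 `C=C[C@@](C)(/C=C/c1ccc(Nc2cccc(OC(F)(F)F)c2)cc1)CCC=C(C)C` differs from compound 2 by trifluoromethoxy in place of hydrogen on an aromatic carbon. Going by the values given here, two measured steps bear on this change. The closer one is a step that the two limits leave unreadable from compound 2 to compound 3, where 3-fluoro-4-methoxyphenyl takes the place of phenyl on a nitrogen. The other is a step that the two limits leave unreadable from compound 1 to compound 2, where anilino takes the place of ((trifluoromethyl)sulfonyl)oxy. Neither step has a size that can be carried over to the new change, so no shift beyond the usual scatter is expected, and neither direction is favoured. The expected result is a number no higher from compound 2 to compound 4 (the limit leaves the size open). A limit rather than a number is the likeliest report from this assay. For compound 4 the estimated value is 52000 nM, with an expected range from 30000 nM to 90000 nM.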

Compound 4, half-maximal effective concentration: > 52000 nM
Compound 4: no number, only a limit; the forecaster's own chance of this, stated with the estimate: 85%; the middle value sits exactly at the limit.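

Going by these compounds alone, compound 2 and compound 4 are each reported only as a limit, so no step between them can be read. The compounds shown leave open which change to the shared core, if any, would give a measurable number in this assay and their one shared mark is this: the limit of > 52000 nM in this assay, at which 4 of the 4 values shown sit.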